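The source may report more compounds than this note shows. Statements on the series, on what has been measured and on what is new or still open speak of the compounds shown alone.

Compound 2 `Cc1ccc(C(F)(F)F)cc1COc1cc(NC(=O)c2ccc(I)cc2)ccc1N(C)S(C)(=O)=O` and compound 1 `CN(c1ccc(NC(=O)c2ccc3ccccc3c2)cc1OCc1cc(Cl)ccc1Cl)S(C)(=O)=O` share a core and differ in two places. In a functional assay on SK-BR-3 cells (Homo sapiens) for antiproliferative activity, read by MTT assay, with a stated time of 48 h (on this read-out higher numbers stand for weaker inhibition and lower numbers for stronger inhibition), compound 2 gives 3500 nM, and compound 1 gives 2210 nM; the two numbers lie within the usual scatter of each other, so neither stands apart. Compound 3 `Cc1ccc(C(F)(F)F)cc1COc1cc(NC(=O)c2ccc3ccccc3c2)ccc1N(C)S(C)(=O)=O` is reached from compound 2 by one change, (naphthalen-2-yl in place of 4-iodophenyl on a carbonyl carbon). Since the two known compounds sit so close together, no step beyond the scatter is expected here. The expected step is a 1.4-fold lower number from compound 2 to compound 3 (0.15 log units; within the scatter). Compound 3 is therefore estimated at 2500 nM, most likely between 1000 nM and 6000 nM.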

Compound 3, half-maximal inhibitory concentration: 18400 nM
Estimate against measurement, compound 3: 7.4-fold (0.87 log units) below; measured number above the stated range.
By their numbers in this assay, from the lowest: compounds 1 and 2 (each within the scatter of the next); then compound 3.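

In this assay the swap of 4-iodophenyl for naphthalen-2-yl on the carbonyl carbon gives a 5.3-fold higher number from compound 2 to compound 3 (0.72 log units; beyond the scatter) and so weaker inhibition, showing that this position is sensitive to its group. Naphthalen-2-yl is not poor everywhere, since 2-methyl-5-(trifluoromethyl)phenyl in place of 2,5-dichlorophenyl on the chain carbon gives an 8.3-fold higher number from compound 1 to compound 3 (0.92 log units; beyond the scatter) with naphthalen-2-yl kept in both compounds. No measurement shown accounts for either step.

Still open, from the compounds shown here alone, is how 4-iodophenyl behaves alongside 2,5-dichlorophenyl. Also open, going by these compounds, is how a plain phenyl or a 4-carboxyphenyl on the carbonyl carbon would compare.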